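A Phenyl Triazole Replaces Sulfamoylamino

This account rests on a few compounds, and the source may have more. Where it says the series, first, only, none or still open, it means among the compounds named here.

In an ADME assay on microsomes from liver (Homo sapiens) for metabolic stability, read by LC-MS, with NADPH named in the record, with a stated time of 60 min, tested at 1 uM, in the absence of a further agent (on this read-out higher numbers stand for a more stable compound and lower numbers for a less stable compound), compound 1 (`COc1ccc(-c2c(C)nc3c(N4CC[C@@H](NC(=O)NC(C)C)C4)cc(C)nn23)cc1OC`) gives only a limit (> 95%). Compound 2 (`COc1ccc(-c2c(C)nc3c(N4CC[C@@H](NS(=O)(=O)c5ccc(C)cc5)C4)cc(C)nn23)cc1OC`) also gives only a limit (> 95%). Compound 3 (`COc1ccc(-c2c(C)nc3c(N4CC[C@@H](NS(N)(=O)=O)C4)cc(C)nn23)cc1OC`) likewise gives only a limit (> 95%). All three sit at one limit (the limit of > 95% in this assay, at which 3 of the 3 values shown sit). Compound 4 (`COc1ccc(-c2c(C)nc3c(N4CC[C@@H](n5cc(-c6ccccc6)nn5)C4)cc(C)nn23)cc1OC`) carries 4-phenyl-1H-1,2,3-triazol-1-yl in place of sulfamoylamino on a saturated ring carbon. The nearest measured steps (a step that the two limits leave unreadable from compound 1 to compound 3 and a step that the two limits leave unreadable from compound 2 to compound 3) have no readable size, so they set no firm expectation. Compound 2 holds a 4-methylphenyl group and stays at its limit (> 95%), so no large fall is expected. A modest downward change is expected (a number at least 10 percentage points lower from compound 3 to compound 4 (that floor lies within the scatter)). For compound 4 the estimate is (85%), with an expected range from 60% to 99% remaining.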

Compound 4, percent of the compound remaining: "unstable" (no number reported)
Compound 4 has no reported number here, and the estimate cannot be compared.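

For the compounds shown here, compound 4 is recorded only as unstable, without a number, and compound 3 holds only a limit, so no step between them can be read. The compounds shown leave open how much stability differs between them.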